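Three inactive amides and a fourth awaiting measurement

A few compounds are considered here, and "the series" means these few. Any claim that something is new, unique, unknown or untested is made for them only; others in the source may bear on it.

Compound 1 `Cc1ccc(N2C(=O)C/C(=C\c3cccc(C(=O)Nc4cccc(F)c4)c3)C2=O)cc1`: in an ADME assay on HCT-116 cells (Homo sapiens) for cytotoxicity, read by MTT assay, with a stated time of 72 h (a higher number here means a weaker inhibitor, a lower number a stronger inhibitor), compound 1 reaches only the assay limit, > 100000 nM.
Compound 2 `COc1ccc(NC(=O)c2cccc(/C=C3\CC(=O)N(c4ccc(C)cc4)C3=O)c2)cc1`: in this assay compound 2 likewise stops at the limit, > 100000 nM.
Compound 3 `CCCCCN1C(=O)C/C(=C\c2cccc(C(=O)Nc3ccc(OC)cc3)c2)C1=O`: in this assay compound 3 also gives a limit and no number, > 100000 nM.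

The change from compound 2 to compound 1 is 3-fluorophenyl in place of 4-methoxyphenyl on an amide-type nitrogen, and its step, a step that the two limits leave unreadable from compound 2 to compound 1, cannot be sized, since both ends are limits. The two cores differ by pentyl in place of 4-methylphenyl on an amide-type nitrogen in a ring, with a step that the two limits leave unreadable from compound 2 to compound 3, again unreadable for the same reason. Compound 4 `CCCCCN1C(=O)C/C(=C\c2cccc(C(=O)Nc3cccc(F)c3)c2)C1=O` carries the change 3-fluorophenyl in place of 4-methoxyphenyl on an amide-type nitrogen on the core of compound 3; the surroundings of the place are the same word for word as in the change from compound 2 to compound 1, so it is the same change. The expectation for compound 4 rests on (the limit of > 100000 nM in this assay, at which 3 of the 3 values shown sit), at which every measured value sits: a step that the limit leaves unreadable from compound 3 to compound 4 is expected, meaning compound 4 is also expected to report only a limit. Compound 4 is therefore estimated at 150000 nM, with an expected range from 100000 nM to 300000 nM.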

Compound 4, half-maximal inhibitory concentration: > 100000 nM
Compound 4 gave a limit, no number; the forecaster's own chance of this, stated with the estimate: 90%; the middle value does not contradict the limit.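

Neither new step, from compound 3 to compound 4 or from compound 1 to compound 4, can be read, since each joins two limits and no number: the limit of > 100000 nM in this assay, at which 4 of the 4 values shown sit.

The compounds shown leave open whether any change at either amide-type nitrogen of the shared core would give a measurable value in this assay.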